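The source may hold more compounds than are shown below. What is called first, only, known or untested is meant among the compounds shown, and "the series" means these compounds.

Measured compounds:
- compound 1, `CCS(=O)(=O)Nc1cccc(-c2cc(=O)n(-c3ccc(C#N)cc3)nc2C)c1`, 39000 nM
- compound 2, `CCS(=O)(=O)Nc1cccc(-c2cc(=O)n(-c3ccc(Cl)c(Cl)c3)nc2C)c1`, 11600 nM
- compound 3, `CCS(=O)(=O)Nc1cccc(-c2cc(=O)n(-c3cc(Cl)cc(Cl)c3)nc2C)c1`, 22900 nM

These three share one core and differ only in the aryl group on the aromatic nitrogen. In a functional assay on LNCaP cells (Homo sapiens) for cytotoxicity, read by cell counting, with a stated time of 2 days (a lower number here means a stronger inhibitor, a higher number a weaker inhibitor), compound 3 gives 22900 nM. Its number is separated from that of compound 1 by a 1.7-fold lower number from compound 1 to compound 3 (0.23 log units; within the scatter) and from that of compound 2 by a 2.0-fold higher number from compound 2 to compound 3 (0.30 log units; within the scatter), so on these three numbers compound 3 cannot be told apart from either neighbour. Among the compounds with values here, the only step beyond the scatter is a 3.4-fold lower number from compound 1 to compound 2 (0.53 log units; beyond the scatter).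

Compound 4, `CCS(=O)(=O)Nc1cccc(-c2cc(=O)n(-c3ccc(F)c(Cl)c3)nc2C)c1`, has not been measured. The change is 3-chloro-4-fluorophenyl in place of 3,5-dichlorophenyl on an aromatic nitrogen. The entering group resembles that of compound 2, with fluorine standing in for one of its two chlorines. Within the data shown here, the steps that bear on this are a 2.0-fold higher number from compound 2 to compound 3 (0.30 log units; within the scatter) and a 3.4-fold lower number from compound 1 to compound 2 (0.53 log units; beyond the scatter), both small. In this assay compound 4 is therefore expected to give a number close to those already seen, with a step of a 1.5-fold lower number from compound 3 to compound 4 (0.18 log units; within the scatter) that likely stays within the scatter. The estimate for compound 4 is 15000 nM, with a range from 6000 nM to 40000 nM.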

Compound 4, half-maximal inhibitory concentration: 26700 nM
For compound 4 the middle estimate is 1.8-fold (0.25 log units) below the measured one, within the range that was stated.
By their numbers in this assay, from the lowest: compounds 2, 3, 4 and 1 (each within the scatter of the next, the first and the last beyond it).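

Fluoro in place of chloro on the 3,4-dichlorophenyl group is the one change here that acts on a single atom, and it gives a 2.3-fold higher number from compound 2 to compound 4 (0.36 log units; beyond the scatter) in this assay, a modest step beyond the scatter. The other two steps, a 1.2-fold higher number from compound 3 to compound 4 (0.07 log units; within the scatter) and a 1.5-fold lower number from compound 1 to compound 4 (0.16 log units; within the scatter), leave 3-chloro-4-fluorophenyl indistinguishable from both 3,5-dichlorophenyl and 4-cyanophenyl, so this single-atom change separates compound 4 only from compound 2. Nothing shown gives a reason for the step from chloro to fluoro.

Within the data shown here, every group at this place so far is a substituted phenyl, so it remains open how an unsubstituted phenyl, a cyclohexyl ring or a phenyl carrying a methoxy group or a carboxylic acid would compare. The ethylsulfonamide on the shared core also stays the same throughout, leaving the effect of a longer chain there unknown.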